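Benzyloxy variation on the acylurea benzimidazole series

A few compounds are considered here, and "the series" means these few. Any claim that something is new, unique, unknown or untested is made for them only; others in the source may bear on it.

Measured so far:
- compound 1, `Cc1ccc(NC(=O)NC(=O)c2ccc(OCc3ccccc3F)cc2)cc1-c1nc2ccccc2[nH]1`, 760 nM
- compound 2, `Cc1ccc(COc2ccc(C(=O)NC(=O)Nc3ccc(C)c(-c4nc5ccccc5[nH]4)c3)cc2)cc1`, 5110 nM

In a functional assay on HT-29 cells (Homo sapiens) for inhibition, read by MTT assay, with a stated time of 48 h (on this read-out higher numbers stand for weaker inhibition and lower numbers for stronger inhibition), compound 2 gives 5110 nM, the highest of the two numbers recorded; its nearest neighbour is compound 1, at 760 nM. Within the data shown here, the one step available, a 6.7-fold higher number from compound 1 to compound 2 (0.83 log units; beyond the scatter), is the whole of what is known about the group on the saturated chain carbon bound to the oxygen on the aromatic ring.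

Compound 3, `Cc1ccc(NC(=O)NC(=O)c2ccc(OCc3cccc(F)c3)cc2)cc1-c1nc2ccccc2[nH]1`, differs from compound 2 by 3-fluorophenyl in place of 4-methylphenyl on a saturated chain carbon bound to an oxygen on an aromatic ring; cut one bond further out, this reads 4-methylbenzyl to 3-fluorobenzyl. The step bearing on it is a 6.7-fold higher number from compound 1 to compound 2 (0.83 log units; beyond the scatter), which shows that replacing a fluorophenyl by 4-methylphenyl at this place gave a modest but real weakening. Compound 3 reverses that replacement, though with 3-fluorophenyl rather than the 2-fluorophenyl of compound 1, so the size of the return is uncertain. In this assay compound 3 is therefore expected to recover part of the loss, a step of a 3.4-fold lower number from compound 2 to compound 3 (0.53 log units; beyond the scatter). The estimate for compound 3 is 1500 nM, with a range from 500 nM to 5000 nM.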

Compound 3, half-maximal inhibitory concentration: 38200 nM
The estimate for compound 3 lay 25-fold (1.41 log units) below the measured number; measured number above the stated range.
By their numbers in this assay, from the lowest: compound 1; then compound 2; then compound 3.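

Notes on the group on the saturated chain carbon bound to an oxygen on an aromatic ring: in this assay, 3-fluorophenyl in place of 2-fluorophenyl gives the only large step in the set (a 50-fold higher number from compound 1 to compound 3 (1.70 log units; beyond the scatter)), so the two fluorophenyl groups are not interchangeable here. 3-Fluorophenyl in place of 4-methylphenyl also weakens inhibition (a 7.5-fold higher number from compound 2 to compound 3 (0.87 log units; beyond the scatter)), which makes compound 3 the weakest of the three, with its steps to both others beyond the scatter. The earlier single step could be read as a contrast between a fluorophenyl and 4-methylphenyl, but that reading no longer holds: the two fluorinated compounds now stand at opposite ends of the order, with the 4-methylphenyl compound 2 between them.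

Nothing available accounts for this order.

As far as these compounds go, it remains open how an unsubstituted phenyl, a chlorophenyl or a pyridine ring would rank at this place, and whether the steep difference between the two fluorophenyl groups would also appear with other groups.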